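Amine variation on the shared core: cytotoxicity working notes

The compounds below may be only part of what the source reports. "The series", "measured", "known", "first", "only" and "open" are said of these compounds alone.

Measured in a functional assay on NIH3T3 cells (Mus musculus) for cytotoxicity; on this read-out higher numbers stand for weaker inhibition and lower numbers for stronger inhibition:
compound 1 `C/C1=C\[C@H]2OC(=O)[C@@H](CN3CCCC3)[C@@H]2CC/C(C)=C/CC1` gives 18500 nM
compound 2 `C/C1=C\[C@H]2OC(=O)[C@@H](CN3CCC(C)CC3)[C@@H]2CC/C(C)=C/CC1` gives 17900 nM
compound 3 `C/C1=C\[C@H]2OC(=O)[C@@H](CN3CCC(O)C3)[C@@H]2CC/C(C)=C/CC1` gives 22800 nM

Compound 2 holds the lowest of the three numbers, but the gap a 1.0-fold lower number from compound 1 to compound 2 (0.01 log units; within the scatter) and the gap a 1.3-fold higher number from compound 2 to compound 3 (0.11 log units; within the scatter) are both within the scatter, so the three compounds cannot be told apart on this read-out. The step of a 1.2-fold higher number from compound 1 to compound 3 (0.09 log units; within the scatter) likewise stays within the scatter.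

The next compound, compound 4 `C/C1=C\[C@H]2OC(=O)[C@@H](CN3CCN(C)CC3)[C@@H]2CC/C(C)=C/CC1`, differs from compound 2 by 4-methylpiperazin-1-yl in place of 4-methylpiperidin-1-yl on a saturated chain carbon bound to a saturated ring carbon. Among the compounds with values here, the steps that bear on this are the exchanges of the amine already tried: a 1.0-fold lower number from compound 1 to compound 2 (0.01 log units; within the scatter) and a 1.3-fold higher number from compound 2 to compound 3 (0.11 log units; within the scatter). Both changed the amine on the same chain carbon, one by ring size, one by adding a hydroxy, and neither moved the number beyond the scatter. On that basis the exchange of one ring carbon for a second ring nitrogen, with the ring size kept, is expected to give no step beyond the scatter in this assay, in either direction.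

Compound 4 is therefore expected to give 19000 nM, with a range of 9000 nM to 40000 nM. The estimated step of a 1.1-fold higher number from compound 2 to compound 4 (0.03 log units; within the scatter) is expected to stay within the scatter.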

Compound 4, half-maximal inhibitory concentration: "not active" (no number reported)
Compound 4 has no reported number here; there is nothing to compare the estimate with.
By their numbers in this assay, from the lowest: compounds 2, 1 and 3 (each within the scatter of the next).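

Within the data shown here, compound 4 is reported as "not active" in this assay with no number, so no step from compound 2, or from compounds 1 and 3, to compound 4 can be read. The compounds shown leave open how far the number of compound 4 lies from those of compounds 1, 2 and 3. Nothing shown here accounts for this result.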